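A benzamido swap on compound 1

This account rests on a few compounds, and the source may have more. Where it says the series, first, only, none or still open, it means among the compounds named here.

Compound 1 `COc1ccc(NC(=O)c2cccc(Nc3ncc(F)c(Nc4ccc(F)cc4)n3)c2)cc1` is the starting point in a functional assay on DU-145 cells (Homo sapiens) for antiproliferative activity, read by sulforhodamine B assay, with a stated time of 3 days; on this read-out higher numbers stand for weaker inhibition of growth and lower numbers for stronger inhibition of growth. In this assay compound 1 gives > 10000 nM, which is a limit of the assay and not a number. Compound 3 `O=C(Nc1cccc(Nc2ncc(F)c(Nc3ccc(F)cc3)n2)c1)c1ccccc1` keeps the core of compound 1 and changes one group: benzamido in place of (4-methoxyphenyl)carbamoyl on an aromatic carbon, meta to a large group (benzamido in place of (4-methoxyphenyl)carbamoyl on an aromatic carbon). Going by the values given here, one measured step bears on this change. Compound 2 `O=C(Nc1cccc(Nc2ncc(F)c(Nc3ccc(F)cc3)n2)c1)c1cnccn1` carries ((pyrazin-2-yl)carbonyl)amino in place of the same (4-methoxyphenyl)carbamoyl, and compound 2 gives 26400 nM. That change is a step that the limit leaves unreadable from compound 1 to compound 2, so it offers no size and no direction to carry over, and the only frame is the limit of > 10000 nM in this assay, at which 1 of the 2 values shown sits. A clear gain in growth inhibition is therefore not expected, and compound 3 should stay in the same weak range, with no step beyond the scatter expected. The expected change is a step that the limit leaves unreadable from compound 1 to compound 3. Compound 3 is estimated at 20000 nM, with an expected range from 7000 nM to 50000 nM.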

Compound 3, concentration for 50% growth inhibition: > 10000 nM
Compound 3 gave a limit, no number (the forecaster's own chance of this, stated with the estimate: 45%); the middle value is on the limit's open side.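

In this assay compound 3 gives > 10000 nM, which is a limit of the assay and not a number. No size or direction can be read for the steps joining compound 3 to compound 1 and compound 2: the limit of > 10000 nM in this assay, at which 2 of the 3 values shown sit.

Going by these compounds, whether benzamido inhibits growth more or less strongly than (4-methoxyphenyl)carbamoyl on this core stays open.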